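One Change on the Phosphate Oxygen of Compound 2

The source may hold more compounds than are shown below. What is called first, only, known or untested is meant among the compounds shown, and "the series" means these compounds.

Three compounds have numbers in a functional assay on U-87MG ATCC cells for cytotoxicity against U-87 MG (Homo sapiens), read by MTT assay, with a stated time of 48 h; a lower number here means a stronger inhibitor, a higher number a weaker inhibitor. Compound 1 `CCOC(=O)C[n+]1cccc(O)c1` gives > 200000 nM, which is a limit of the assay rather than a number (the limit of > 200000 nM in this assay, at which 1 of the 3 values shown sits). Compound 2 `O=C(O[C@H]1C[C@H](n2cc(F)c(=O)[nH]c2=O)O[C@@H]1COP(=O)(O)Oc1cccnc1)c1ccccc1` gives 710 nM in this assay. Compound 3 `O=C(O[C@H]1C[C@H](n2cc(F)c(=O)[nH]c2=O)O[C@@H]1COP(=O)(O)Oc1ccc2ncccc2c1)c1ccccc1` gives 880 nM in this assay, and the step of a 1.2-fold higher number from compound 2 to compound 3 (0.09 log units; within the scatter) is within the scatter. Compound 2 thus holds the lowest of the two numbers shown, with compound 3 within the scatter of it and the third value being only a limit.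

Compound 4 `C[N+]1(C)CCC(OP(=O)([O-])OC[C@H]2O[C@@H](n3cc(F)c(=O)[nH]c3=O)C[C@@H]2OC(=O)c2ccccc2)CC1` differs from compound 2 by a group of 12 heavy atoms (7 carbon, 1 nitrogen, 3 oxygen, 1 phosphorus; one six-membered non-aromatic ring with 1 hetero atom) in place of a group of 10 heavy atoms (5 carbon, 1 nitrogen, 3 oxygen, 1 phosphorus; one six-membered aromatic ring with 1 hetero atom), on an oxygen on a saturated carbon. For the measured compounds named here, the only measured step that touches this oxygen is a 1.2-fold higher number from compound 2 to compound 3 (0.09 log units; within the scatter), which stayed within the scatter; no measured step covers a six-membered non-aromatic ring at this place. The account therefore expects a small step, if any, in this assay. The expected step is a 2.0-fold higher number from compound 2 to compound 4 (0.29 log units; within the scatter). Compound 4 is estimated to give 1400 nM in this assay, within a range from 450 nM to 4500 nM.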

Compound 4, half-maximal inhibitory concentration: 1280 nM
Compound 4: the middle estimate sits 1.1-fold (0.04 log units) above what was measured; the range from low to high includes it.
By their numbers in this assay, from the lowest: compounds 2, 3 and 4 (each within the scatter of the next). At a limit, above all of these: compound 1.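

In this assay the change at this oxygen gives a 1.8-fold higher number from compound 2 to compound 4 (0.26 log units; within the scatter) and so stays within the scatter. The earlier step at this place only exchanged one aromatic group for another, whereas this one puts a six-membered non-aromatic ring with 1 hetero atom in place of a six-membered aromatic ring with 1 hetero atom. Across this change, then, the number does not depend on an aromatic ring at this place, at least for this pair of groups. Nothing in the evidence at hand bears on why this step is so small. The compounds shown leave open whether an open-chain group, such as a longer alkyl chain, or a ring carrying a carboxylic acid or a primary amine would also stay within the scatter at this oxygen.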